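Piperidine for methylpiperazine on the amide chain

The source may hold more compounds than are shown below. What is called first, only, known or untested is meant among the compounds shown, and "the series" means these compounds.

Within the data shown here, compound 2 `CN1CCN(CC(=O)Nc2ccc(-c3nc4cc(C(F)(F)F)ccc4n3C)cc2)CC1` stands at the lower of the two numbers measured so far: in an ADME assay on BHK cells (Mesocricetus auratus) for cytotoxicity, read by MTT assay, with a stated time of 96 h (on this read-out lower numbers stand for higher toxicity in this test and higher numbers for lower toxicity in this test), compound 2 gives 16000 nM, while compound 1 `CN1CCN(CC(=O)Nc2ccc(-c3nc4cc(Cl)c(Cl)cc4[nH]3)cc2)CC1` gives 41000 nM, a gap beyond the scatter. Compound 3 `Cn1c(-c2ccc(NC(=O)CN3CCCCC3)cc2)nc2cc(C(F)(F)F)ccc21` is not yet measured. Relative to compound 2 the change is piperidin-1-yl in place of 4-methylpiperazin-1-yl on a saturated chain carbon bound to a carbonyl carbon. Among the measured compounds shown here, no step between measured compounds covers this change, so in this assay a step no larger than the scatter, in either direction, is expected, a 1.1-fold lower number from compound 2 to compound 3 (0.06 log units; within the scatter). Compound 3 is accordingly estimated at 14000 nM, with a range from 5000 nM to 40000 nM.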

Compound 3, half-maximal cytotoxic concentration: > 100000 nM
Compound 3: only a limit was reported (the forecaster's own chance of this, stated with the estimate: 10%); middle value at least 7.1-fold (0.85 log units) from the limit.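

On the saturated chain carbon bound to a carbonyl carbon, the ring is not a silent place in this assay: piperidin-1-yl in place of 4-methylpiperazin-1-yl gives an at least 6.2-fold higher number from compound 2 to compound 3 (0.79 log units; beyond the scatter), towards lower toxicity in this test. Compound 1 and compound 2 differ in more than one place, so they gave no reading on this position. The reading for compound 3 is a limit, not a number: the limit of > 100000 nM in this assay, at which 1 of the 3 values shown sits.

From the compounds shown here alone, whether morpholine or an unsubstituted piperazine at this place would read with compound 2 or with compound 3 stays open. So does whether the same exchange on the core of compound 1 gives a step of similar size.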